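The source may report more compounds than this note shows. Statements on the series, on what has been measured and on what is new or still open speak of the compounds shown alone.

Measured so far:
- compound 1, `Cc1cc(C)c(-c2cn(C)cn2)cc1NC(=O)c1ccc(OCc2ccccn2)cc1`: 87%
- compound 2, `Cc1ncc(-c2cc(NC(=O)c3ccc(OCc4ccccn4)cc3)c(C)cc2C)[nH]1`: 81%
- compound 3, `Cc1ccc(-c2ncc[nH]2)c(C)c1NC(=O)c1ccc(OCc2ccccn2)cc1`: 0%

In a functional assay on the whole organism (COLO 205 cells) for inhibition, with Mus musculus as the target, read by polymerase chain reaction, in a xenograft, with a stated time of 8 h, at a dose of 40 mg/kg by the oral route (on this read-out lower numbers stand for less inhibition and higher numbers for more inhibition at the one dose given (going by the name of the read-out)), compound 2 gives 81%, the second highest of the three numbers. Its nearest neighbour is compound 1, whose number is higher by an amount within the scatter; compound 3 lies far below it, beyond the scatter.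

The unmeasured compound 4, `Cc1cc(C)c(-c2ccc(N)nn2)cc1NC(=O)c1ccc(OCc2ccccn2)cc1`, differs from compound 2 in one place: 6-aminopyridazin-3-yl in place of 2-methyl-1H-imidazol-5-yl on an aromatic carbon.

Among the measured compounds shown here, only one measured step bears on this change, the one from compound 1 to compound 2, where one five-membered ring with two hetero atoms was swapped for another, giving a number 6 percentage points lower from compound 1 to compound 2 (within the scatter). That step says that a swap among such rings at this place leaves the number level, but it involved no six-membered ring and no added amino group, so the step to a 6-aminopyridazin-3-yl is less predictable. Compound 3 offers no guidance, since its ring sits on a differently arranged core.

Compound 4 is therefore expected to keep a high number in this assay, with a step of a number 16 percentage points lower from compound 2 to compound 4 (beyond the scatter), and its estimate in this assay is 65%, within 20% to 95%.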

Compound 4, a percentage reported as inhibition, in the whole organism at one dose (the size of the read-out at that dose, not a potency): 80%
For compound 4 the middle estimate is 15 percentage points below the measured one; the range from low to high includes it.
By their numbers in this assay, from the lowest: compound 3; then compounds 4, 2 and 1 (each within the scatter of the next).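

In this assay, swapping the five-membered ring for 6-aminopyridazin-3-yl gives a number 1 percentage points lower from compound 2 to compound 4 (within the scatter), and the comparison with the other imidazole gives a number 7 percentage points lower from compound 1 to compound 4 (within the scatter). Among the compounds shown here, the earlier step compared only two five-membered aromatic rings, whereas these steps show that, at this place on the shared core, a six-membered aromatic ring with an amino group can also give a number within the scatter of both imidazole compounds. Nothing measured here explains this result.

The six-membered ring and the amino group enter together, so the compounds shown leave open what each contributes; a plain pyridazin-3-yl without the amine and a phenyl ring carrying an amine would pull the two apart. Going by these compounds, whether a carboxylic acid on the same ring would fit at this place also remains open.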